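A few compounds are considered here, and "the series" means these few. Any claim that something is new, unique, unknown or untested is made for them only; others in the source may bear on it.

Compound 1 `CC1(Sc2ccccc2)C(=O)N(c2ccccc2)c2ncccc21` and compound 2 `CC1(C)C(=O)N(Cc2ccc(Cl)cc2)c2ncccc21` were both tested in a functional assay on the whole organism (Pleural cavity) for inhibition, with Rattus norvegicus as the target, at a dose of 25 mg/kg; a lower number here means less inhibition, a higher number more inhibition at the dose given (going by the name of the read-out). In this assay compound 1 gives 0%, while compound 2 gives 6%; the two numbers lie within the scatter of each other, and compound 1 holds the lower of the two. Compound 3 `CC1C(=O)N(c2ccccc2)c2ncccc21` is the next compound, differing from compound 1 by the change (hydrogen in place of phenylsulfanyl on a saturated ring carbon). With both measured compounds low, the step is expected to be small, a number 5 percentage points higher from compound 1 to compound 3 (within the scatter), in no direction beyond the scatter. Compound 3 is therefore estimated to give about 5%, between 0% and 20%.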

Compound 3, a percentage reported as inhibition, in the whole organism at one dose (the size of the read-out at that dose, not a potency): 29%
The estimate for compound 3 lay 24 percentage points below the measured number; measured number outside the range, above it.
By their numbers in this assay, from the lowest: compounds 1 and 2 (each within the scatter of the next); then compound 3.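

In this assay, hydrogen in place of phenylsulfanyl on a saturated ring carbon brings a number 29 percentage points higher from compound 1 to compound 3 (beyond the scatter) and so takes the read-out clear of the scatter. This shows that the group at this position matters to the read-out at the dose given, which the two earlier compounds could not show without a single-place step between them. Nothing available explains the step. On these data alone, whether the sulfur or the phenyl ring accounts for it stays open, as does how a methylsulfanyl group, an amine or a carboxylic acid on this carbon would read.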